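The source may report more compounds than this note shows. Statements on the series, on what has been measured and on what is new or still open speak of the compounds shown alone.

Working notes on the hydrazone series.

Three compounds have been run in a functional assay, with a stated time of 30 min; a higher number here means that more compound is needed for the effect, a lower number that less compound is needed. Compound 1 `CC/C(C)=N\Nc1nc(-c2cccc([N+](=O)[O-])c2)cs1` gives 580000 nM. Compound 2 `CCC/C(C)=N\Nc1nc(-c2cccc([N+](=O)[O-])c2)cs1` gives 550000 nM. Compound 3 `CCCCC/C(CC)=N\Nc1nc(-c2cccc([N+](=O)[O-])c2)cs1` gives 590000 nM. The three numbers sit close together: the step of a 1.1-fold higher number from compound 2 to compound 1 (0.02 log units; within the scatter) is within the scatter, and compound 3 differs from compound 1 and from compound 2 by amounts that are also within the scatter, so no order among the three can be read from these data.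

The change from compound 2 to compound 1 is hydrogen in place of methyl on a saturated chain carbon, two bonds along the chain from a carbon with a double bond to nitrogen. The difference between the cores of compound 3 and compound 2 is not broken down here.

Compound 4 `CCCC/C(CC)=N\Nc1nc(-c2cccc([N+](=O)[O-])c2)cs1` has not yet been measured in this assay. It differs from compound 3 by hydrogen in place of methyl on a saturated chain carbon, four bonds along the chain from a carbon with a double bond to nitrogen. Among the compounds with values here, this is the same kind of change as the one from compound 2 to compound 1, but not the same: there the methyl leaves from a saturated chain carbon two bonds along the chain from the carbon with a double bond to nitrogen, here from one four bonds along. Within the data shown here, the one measured instance, a 1.1-fold higher number from compound 2 to compound 1 (0.02 log units; within the scatter), sat within the scatter, and the three measured values give no sign that chain length moves the read-out.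

For compound 4 the expected step is a 1.0-fold lower number from compound 3 to compound 4 (0.01 log units; within the scatter), resting on compound 2 to compound 1 showing a 1.1-fold higher number from compound 2 to compound 1 (0.02 log units; within the scatter). Compound 4 is therefore estimated at 580000 nM in this assay, with an expected range of 300000 nM to 1100000 nM.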

Compound 4, half-maximal effective concentration: 550000 nM
Compound 4: the middle estimate sits 1.1-fold (0.02 log units) above what was measured, and the stated range covers the measured number.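

In this assay, the new step is a 1.1-fold lower number from compound 3 to compound 4 (0.03 log units; within the scatter), for hydrogen in place of methyl on a saturated chain carbon, four bonds along the chain from a carbon with a double bond to nitrogen. Set beside the earlier instance of this kind of change, the two steps show no difference: the same change on two cores in this assay, a 1.1-fold higher number (0.02 log units; within the scatter) from compound 2 to compound 1 and a 1.1-fold lower number (0.03 log units; within the scatter) from compound 3 to compound 4, 1.1-fold (0.05 log units) apart, within the scatter of two such steps. Within these two pairs, the change therefore carries from one core to the other in the sense that neither step can be told from the scatter, but the methyl leaves from a different chain place in each pair, and two small steps do not show that the change would stay silent on other cores or at other chain places.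

The compounds shown leave open whether any group on this chain can move the read-out beyond the scatter, for example an amine, a carboxylic acid or a longer chain in place of the simple chains tested here. They also leave open what a change to the shared core would do, as every compound shown carries that core unchanged.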